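Methoxy to ethoxy step in a cytotoxicity series

A few compounds are considered here, and "the series" means these few. Any claim that something is new, unique, unknown or untested is made for them only; others in the source may bear on it.

Measured compounds:
compound 1, `COc1ccc(NC(=O)c2cn(-c3ccccc3)nc2-c2ccc(Cl)cc2)cc1`, 1550 nM
compound 2, `CCOc1ccc(NC(=O)c2cn(-c3ccccc3)nc2-c2ccc(Cl)cc2)cc1`, 560 nM
compound 3, `COc1ccc(NC(=O)c2cn(-c3ccccc3)nc2-c2ccc([N+](=O)[O-])cc2)cc1`, 1210 nM

In a functional assay on MCF7 cells (Homo sapiens) for cytotoxicity, read by MTT assay, with a stated time of 48 h (a lower number here means a stronger inhibitor, a higher number a weaker inhibitor), compound 1 gives 1550 nM. Compound 2 gives 560 nM, and compound 3 gives 1210 nM.

Compound 1 and compound 2 differ by methyl in place of hydrogen on a saturated chain carbon bound to an oxygen on an aromatic ring, and this change gives a 2.8-fold lower number from compound 1 to compound 2 (0.44 log units; beyond the scatter). The cores of compound 1 and compound 3 differ by nitro in place of chloro on an aromatic carbon, which gives a 1.3-fold lower number from compound 1 to compound 3 (0.11 log units; within the scatter); the two values are within the usual scatter of each other, so no order between compound 1 and compound 3 is claimed.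

Compound 4, `CCOc1ccc(NC(=O)c2cn(-c3ccccc3)nc2-c2ccc([N+](=O)[O-])cc2)cc1`, has not yet been measured in this assay. It differs from compound 3 by methyl in place of hydrogen on a saturated chain carbon bound to an oxygen on an aromatic ring. The place is the same, word for word, as in the change from compound 1 to compound 2, so this is the same change, occurring twice among the four compounds, once measured and once not.

Among the measured compounds shown here, only one measured instance of the change exists, so the expectation rests on a single step. A step of a 2.7-fold lower number from compound 3 to compound 4 (0.43 log units; beyond the scatter) is expected from compound 3 to compound 4, because a 2.8-fold lower number from compound 1 to compound 2 (0.44 log units; beyond the scatter) was seen on the core of compound 1 and the cores differ only by nitro in place of chloro on an aromatic carbon. Compound 4 is expected to give about 450 nM in this assay. The range expected for compound 4 runs from 200 nM to 1000 nM, widened because a 1.3-fold lower number from compound 1 to compound 3 (0.11 log units; within the scatter) shows the core change alone falls within the scatter, leaving the transfer of the ethoxy step to the nitro core untested.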

Compound 4, half-maximal inhibitory concentration: 460 nM
The estimate for compound 4 lay 1.0-fold (0.01 log units) below the measured number; measured number inside the range.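

In this assay, the methoxy to ethoxy change carries from the core of compound 1 to the core of compound 3, with a 2.6-fold lower number from compound 3 to compound 4 (0.42 log units; beyond the scatter), and the two steps agree: the same change on two cores in this assay, a 2.8-fold lower number (0.44 log units; beyond the scatter) from compound 1 to compound 2 and a 2.6-fold lower number (0.42 log units; beyond the scatter) from compound 3 to compound 4, 1.1-fold (0.02 log units) apart, within the scatter of two such steps The nitro in place of chloro change stays within the scatter on the ethoxy pair as well, with a 1.2-fold lower number from compound 2 to compound 4 (0.09 log units; within the scatter), so no order between these two compounds is claimed, and this matches the methoxy pair: the same change on two cores in this assay, a 1.3-fold lower number (0.11 log units; within the scatter) from compound 1 to compound 3 and a 1.2-fold lower number (0.09 log units; within the scatter) from compound 2 to compound 4, 1.1-fold (0.02 log units) apart, within the scatter of two such steps Together the four compounds form a closed square in which the two changes combine without visible interaction, but this rests on two cores in a single assay and does not show that the ethoxy step would hold on any other core, nor does it explain the size of the step.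

Going by these compounds, it remains open whether the gain from methoxy to ethoxy continues with a propoxy group or a longer chain, or whether a hydroxyl in that place loses it. On these data alone, it is also open whether the step persists when an amine or a carboxylic acid stands in place of the nitro or chloro group on the aromatic carbon.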